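This account rests on a few compounds, and the source may have more. Where it says the series, first, only, none or still open, it means among the compounds named here.

In an ADME assay on HepG2 cells (Homo sapiens) for antiproliferative activity, read by MTT assay, with a stated time of 72 h (a higher number here means a weaker inhibitor, a lower number a stronger inhibitor), compound 3, whose structure is `Cc1ccc(NC(=O)c2cccc(C(C)(C)C)c2)cc1C#Cc1nn([C@H]2CC[C@H](O)CC2)c2ncnc(N)c12`, gives 4400 nM. For the measured compounds named here, of the two numbers recorded in this assay, that value sits alongside the one for compound 2, with structure `Cc1ccc(C(=O)Nc2cccc(C(F)(F)F)c2)cc1C#Cc1nn(CC2CCN(C)C2)c2ncnc(N)c12`, which gives 3500 nM, and the gap between them lies within the scatter. Compound 1, with structure `CCn1nc(C#Cc2cc(C(=O)Nc3cccc(C(F)(F)F)c3)ccc2C)c2c(N)ncnc21`, reaches only the limit of the assay at > 10000 nM; this is a limit rather than a number, as noted in the limit of > 10000 nM in this assay, at which 1 of the 3 values shown sits. Going by the values given here, the one measured step, an at least 2.8-fold lower number from compound 1 to compound 2 (0.45 log units; beyond the scatter), concerns the group on the nitrogen of the shared core, not the amide side.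

Compound 4 has the structure `Cc1ccc(NC(=O)c2ccc(Cl)c(C(F)(F)F)c2)cc1C#Cc1nn([C@H]2CC[C@H](O)CC2)c2ncnc(N)c12`. It differs from compound 3 by 4-chloro-3-(trifluoromethyl)phenyl in place of 3-(tert-butyl)phenyl on a carbonyl carbon. Among the compounds with values here, no measured step touches this carbonyl-bound ring, so the step from compound 1 to compound 2 offers no direct guide, and the expected change is none beyond the scatter, with a lean toward a somewhat lower number. Compound 4 is therefore estimated at 3000 nM, within a range from 1000 nM to 10000 nM, which means an expected step of a 1.5-fold lower number from compound 3 to compound 4 (0.17 log units; within the scatter).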

Compound 4, half-maximal inhibitory concentration: > 10000 nM
Compound 4: a limit, no number (the forecaster's own chance of this, stated with the estimate: 15%); middle value at least 3.3-fold (0.52 log units) from the limit.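

For the compounds shown here, the ring on the carbonyl carbon, which no earlier step touched, also moves the result in this assay: 4-chloro-3-(trifluoromethyl)phenyl in place of 3-(tert-butyl)phenyl gives an at least 2.2-fold higher number from compound 3 to compound 4 (0.35 log units; beyond the scatter). The earlier step showed a change in the group on the nitrogen of the shared core, and this one shows that the carbonyl-bound ring matters too, here in the direction of a weaker inhibitor. Compound 4 gives a limit, not a number, and it is the same limit as for compound 1: the limit of > 10000 nM in this assay, at which 2 of the 4 values shown sit.

The compounds shown leave open whether the chlorine or the trifluoromethyl group accounts for this step, since the two enter together. They also leave open how a ring on this carbonyl carbon carrying an amine, such as a dimethylamino group, would behave.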